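A few compounds are considered here, and "the series" means these few. Any claim that something is new, unique, unknown or untested is made for them only; others in the source may bear on it.

Measured compounds:
Compound 1 `COc1ccc(Nc2cc(Oc3c(C)cc(Br)cc3C)c([N+](=O)[O-])cc2[N+](=O)[O-])cc1` gives 51200 nM.
Compound 2 `COc1ccc(Nc2cc(Oc3c(C)cccc3C)c([N+](=O)[O-])cc2[N+](=O)[O-])cc1` gives a limit of the assay, > 61100 nM.
Compound 3 `Cc1cccc(C)c1Oc1cc(Nc2ccc(C#N)cc2)c([N+](=O)[O-])cc1[N+](=O)[O-]` gives a limit of the assay, > 61800 nM.

In an ADME assay on H9 cells (Homo sapiens) for cytotoxicity, read by XTT assay, with a stated time of 6 days (on this read-out lower numbers stand for higher toxicity in this test and higher numbers for lower toxicity in this test), compound 1 gives 51200 nM. For compound 2 the reading is a limit of the assay, > 61100 nM. For compound 3 the reading is likewise a limit, > 61800 nM. The change bromo in place of hydrogen on an aromatic carbon made an at least 1.1-fold lower number from compound 2 to compound 1 (0.07 log units; that floor lies within the scatter), and it can be read only as a floor because of the limit of > 61100 nM in this assay, at which 1 of the 3 values shown sits. The two cores differ by cyano in place of methoxy on an aromatic carbon, and here a step that the two limits leave unreadable from compound 2 to compound 3, since both the limit of > 61100 nM in this assay, at which 1 of the 3 values shown sits, and the limit of > 61800 nM in this assay, at which 1 of the 3 values shown sits, sit at the limit.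

Compound 4 `Cc1cc(Br)cc(C)c1Oc1cc(Nc2ccc(C#N)cc2)c([N+](=O)[O-])cc1[N+](=O)[O-]` is not yet measured; it differs from compound 3 by bromo in place of hydrogen on an aromatic carbon, the same change as that from compound 2 to compound 1, at a place described in the same words. Since that earlier step was no larger than the scatter, the step of an at least 1.2-fold lower number from compound 3 to compound 4 (0.09 log units; that floor lies within the scatter) is expected to be small as well, resting on an at least 1.1-fold lower number from compound 2 to compound 1 (0.07 log units; that floor lies within the scatter) and on the limit of compound 3, > 61800 nM. Compound 4 is therefore estimated at 50000 nM, expected between 20000 nM and 70000 nM, with a fair chance that only a limit is reported.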

Compound 4, half-maximal cytotoxic concentration: > 51700 nM
Compound 4: only a limit was reported; the forecaster's own chance of this, stated with the estimate: 45%; middle value at least 1.0-fold (0.01 log units) away from the limit.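

In this assay compound 4 gives only a limit of the assay (> 51700 nM). Neither new step can be read for size, and the one for cyano in place of methoxy amounts to no more than a number no lower from compound 1 to compound 4 (the limit leaves the size open), because compound 4 stands at a limit: the limit of > 51700 nM in this assay, at which 1 of the 4 values shown sits. Within the data shown here, the series therefore does not show whether bromo in place of hydrogen acts alike on the two cores, nor that it acts differently; it shows only that compound 4, like compound 3, gave a limit and not a number.

The compounds shown leave open how this change would read on a core where both partners give a number. Also open, from the compounds shown here alone, is what an amine or a carboxylic acid in place of the nitrile or the methoxy would do to the reading in this assay.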